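Working notes: chloro in place of fluoro, compound 4

The source may hold more compounds than are shown below. What is called first, only, known or untested is meant among the compounds shown, and "the series" means these compounds.

Of the compounds shown here, three have been measured in a functional assay on HCT-116 cells (Homo sapiens) for inhibition, read by CCK-8 assay, with a stated time of 72 h, tested at 2 uM; a lower number here means less inhibition of growth, a higher number more inhibition of growth at the concentration tested. Compound 1 `COc1ccc(SCc2ccc(C(=O)Nc3ccccc3N)cc2)cc1` gives 73.3%, compound 2 `CC(C)(C)c1ccc(SCc2ccc(C(=O)Nc3ccccc3N)cc2)cc1` gives 4.81% and compound 3 `Nc1ccccc1NC(=O)c1ccc(CSc2ccc(F)cc2)cc1` gives 13.5%. Compound 3 therefore stands well apart from compound 1, with a number 59.8 percentage points lower from compound 1 to compound 3 (beyond the scatter). Its distance from compound 2 is not resolved by this read-out, with a number 8.7 percentage points higher from compound 2 to compound 3 (within the scatter).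

Compound 4 `Nc1ccccc1NC(=O)c1ccc(CSc2ccc(Cl)cc2)cc1` differs from compound 3 in one place: chloro in place of fluoro on an aromatic carbon. This is chloro in place of fluoro on an aromatic carbon, para to a large group.

Going by the values given here, no measured step involves chloro, so the estimate rests on indirect evidence from changes at this place. The two large steps both start from the methoxy group of compound 1: a number 68.5 percentage points lower from compound 1 to compound 2 (beyond the scatter) and a number 59.8 percentage points lower from compound 1 to compound 3 (beyond the scatter). Among the compounds with values here, the only measured step without methoxy, a number 8.7 percentage points higher from compound 2 to compound 3 (within the scatter), stays within the scatter. The swap to compound 4 also involves no methoxy, so a small upward change is expected, with a real chance of a larger one. The expected step is a number 6.5 percentage points higher from compound 3 to compound 4 (within the scatter), which would not clearly separate the two compounds. The estimated value for compound 4 is 20%, with an expected range from 6% to 45%.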

Compound 4, percent growth inhibition at one concentration: 17.5%
Compound 4: the middle estimate sits 2.5 percentage points above what was measured; the range from low to high includes it.
By their numbers in this assay, from the lowest: compounds 2, 3 and 4 (each within the scatter of the next, the first and the last beyond it); then compound 1.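

In (this assay), the change from 4-fluorophenyl to 4-chlorophenyl gives (a number 4 percentage points higher from compound 3 to compound 4 (within the scatter)), so this read-out does not separate the two halogens at this place, and compound 3 and compound 4 have to be treated as equivalent here. Chloro does what fluoro did not do and stands clear of tert-butyl, though only modestly (a number 12.7 percentage points higher from compound 2 to compound 4 (beyond the scatter)), while the much larger step from methoxy (a number 55.8 percentage points lower from compound 1 to compound 4 (beyond the scatter)) shows that a second halogen also fails to come near compound 1, leaving methoxy alone at the high end among the four compounds. Nothing measured here bears on why the groups at this place fall out in this way.

Still open, going by these compounds, is whether the large gap to compound 1 belongs to methoxy alone or would also appear with ethoxy, hydroxy or a dimethylamino group at this place. Also open, on these data alone, are where bromo would fall relative to fluoro and chloro, and whether compounds that one tested concentration cannot separate would separate across a range of concentrations.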